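Amino to fluoro on the benzamidine ring: expectation

This account rests on a few compounds, and the source may have more. Where it says the series, first, only, none or still open, it means among the compounds named here.

Compound 1 `N=C(N)c1ccc(N)c(CN2CC[C@H](NS(=O)(=O)c3ccc(-c4cccnc4)s3)C2=O)c1` is measured in an assay on isolated protein for inhibition of Trypsin II (Bos taurus) (on this read-out lower numbers stand for stronger inhibition and higher numbers for weaker inhibition), at 1500 nM. It holds the lowest of the two numbers shown; its nearest neighbour, compound 2 `N=C(N)c1ccc(N)c(CN2CC[C@H](NS(=O)(=O)c3ccc(-c4ccon4)s3)C2=O)c1`, gives 1700 nM, and the step of a 1.1-fold higher number from compound 1 to compound 2 (0.05 log units; within the scatter) is within the scatter. Compound 3 `COc1ccc2ccc(S(=O)(=O)N(C)[C@H]3CCN(Cc4cc(C(=N)N)ccc4NC(C)=O)C3=O)cc2c1` reaches only the limit of this assay and gives > 2900 nM; that value is a limit, not a number (the limit of > 2900 nM in this assay, at which 1 of the 3 values shown sits).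

Compound 4 `N=C(N)c1ccc(F)c(CN2CC[C@H](NS(=O)(=O)c3ccc(-c4cccnc4)s3)C2=O)c1` differs from compound 1 in one place: fluoro in place of amino on an aromatic carbon. The group lies on an aromatic carbon of a six-membered aromatic ring of carbon only, ortho to a large group and para to a group of 3 heavy atoms. Among the compounds with values here, none of the measured steps touches this position; the one step measured, from compound 1 to compound 2, changes a distal heteroaryl and is within the scatter, so it gives no direction for an amino-to-fluoro exchange.

The estimate for compound 4 therefore rests on compound 1 alone and assumes a step of a 1.5-fold higher number from compound 1 to compound 4 (0.17 log units; within the scatter) of modest size, if any, beyond the scatter in this assay. Compound 4 is expected at about 2200 nM, within a range from 700 nM to 7000 nM.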

Compound 4, inhibition constant: > 2900 nM
Compound 4: no number, only a limit; the forecaster's own chance of this, stated with the estimate: 35%; middle value at least 1.3-fold (0.11 log units) from the limit.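

Fluoro in place of amino on the aromatic carbon ortho to a large group is the first change shown at this position, and in this assay compound 4 returns a limit, not a number. Read as a floor, the exchange gives an at least 1.9-fold higher number from compound 1 to compound 4 (0.28 log units; that floor lies within the scatter), so it brings no lower number, while the true size of any rise stays unresolved. Among the single exchanges shown, only this one takes the read-out out of the numeric range, and no finer reading is available there: the limit of > 2900 nM in this assay, at which 2 of the 4 values shown sit.

Going by these compounds, whether a hydroxyl, a methoxy or a methylamino group on this carbon would give a number within range remains open. Also open, on these data alone, is whether a plain hydrogen there would separate the effect of losing amino from that of adding fluoro.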